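This account rests on a few compounds, and the source may have more. Where it says the series, first, only, none or still open, it means among the compounds named here.

Measured compounds and their values:
- compound 1 `CC(=O)Oc1ccccc1C(=O)O[C@H]1CO[C@H]2[C@@H]1OC[C@H]2OC(=O)c1ccccc1O`: 0.019 h
- compound 2 `CC(=O)Oc1ccccc1C(=O)O[C@H]1CO[C@H]2[C@@H]1OC[C@H]2OC(=O)c1ccc(O)cc1`: 0.0198 h
- compound 3 `COc1cccc(C(=O)O[C@@H]2CO[C@H]3[C@@H]2OC[C@@H]3OC(=O)c2ccccc2OC(C)=O)c1`: 0.0142 h

All three values come from an ADME assay on a cell-free system (plasma, Homo sapiens) for metabolic stability, with Plasma (Rattus norvegicus) as the target, read by HPLC, at pH 7.4; on this read-out lower numbers stand for a shorter-lived compound and higher numbers for a longer-lived compound. Compound 1 stands second highest of the three numbers, but every gap between these compounds lies within the scatter: the step of a 1.0-fold higher number from compound 1 to compound 2 (0.02 log units; within the scatter), the step of a 1.3-fold lower number from compound 1 to compound 3 (0.13 log units; within the scatter) and the step of a 1.4-fold lower number from compound 2 to compound 3 (0.14 log units; within the scatter) are all small. Each of these steps swaps only a substituent on the phenyl ring of one ester group, and none of them moves the read-out beyond the usual noise.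

Compound 4 `CC(=O)Oc1ccccc1C(=O)O[C@H]1CO[C@H]2[C@@H]1OC[C@H]2O[N+](=O)[O-]` is not yet measured. It differs from compound 1 by nitro in place of (2-hydroxyphenyl)carbonyl on an oxygen on a saturated carbon. This is a larger change than any of the measured steps: a whole aromatic ester group leaves and a far smaller group takes its place on the same oxygen. Among the compounds with values here, no measured pair shows exactly this kind of exchange, so the measured steps give only indirect guidance. Because the three measured steps of a 1.0-fold higher number from compound 1 to compound 2 (0.02 log units; within the scatter), a 1.3-fold lower number from compound 1 to compound 3 (0.13 log units; within the scatter) and a 1.4-fold lower number from compound 2 to compound 3 (0.14 log units; within the scatter) all stay within scatter, the expectation is that compound 4 also stays close to compound 1 in this assay, with a wider range to allow for the larger change.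

Compound 4 is therefore estimated at 0.025 h, within a range of 0.01 h to 0.065 h, an expected step of a 1.3-fold higher number from compound 1 to compound 4 (0.12 log units; within the scatter).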

Compound 4, half-life: 0.00314 h
Beside the measured number, compound 4's estimate is 8.0-fold (0.90 log units) above it; measured number below the stated range.
By their numbers in this assay, from the lowest: compound 4; then compounds 3, 1 and 2 (each within the scatter of the next).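

In this assay the oxygen on a saturated carbon proves to be a place where the read-out does respond: nitro in place of the aromatic ester gives a 6.1-fold lower number from compound 1 to compound 4 (0.78 log units; beyond the scatter) and the same kind of exchange gives a 4.5-fold lower number from compound 3 to compound 4 (0.66 log units; beyond the scatter) and also a 6.3-fold lower number from compound 2 to compound 4 (0.80 log units; beyond the scatter) in the other two pairs. All three steps lie beyond the scatter and point towards a shorter-lived compound, whereas changing only the substituent on the phenyl ring among compounds 1, 2 and 3 stayed within the scatter, so in this small set replacing the whole ester group matters more than altering its ring. Nothing shown here explains this shift or identifies what happens to compound 4.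

Going by these compounds, it remains open whether the shorter half-life belongs to nitro itself or follows from the departure of the aromatic ester, a question that a methyl ether or a chain ending in an amine on the same oxygen could help to separate. On these data alone, it is also open whether the exchange would have a similar size if the other ester on the shared core were different.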